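The source may report more compounds than this note shows. Statements on the series, on what has been measured and on what is new or still open speak of the compounds shown alone.

Compound 3 `CCOC(=O)c1cc([Se]Cc2ccccc2)c2cc(OC)ccc2n1` gives 20800 nM in a functional assay on Jurkat cells (Homo sapiens) for cytotoxicity, read by MTT assay, with a stated time of 24 h (on this read-out higher numbers stand for an effect only at larger amounts of compound and lower numbers for an effect already at smaller amounts), the second highest of the three numbers. Compound 1 `CCOC(=O)c1cc([Se]c2ccccc2C)c2cc(OC)ccc2n1` is nearest with 14900 nM. Compound 2 `CCOC(=O)c1cc([Te]c2ccccc2)c2cc(OC)ccc2n1` is furthest with 77400 nM. Compound 4 `CCOC(=O)c1cc([Se]c2ccc(F)cc2)c2cc(OC)ccc2n1` differs from compound 3 by 4-fluorophenyl in place of benzyl on a selenium. Among the measured compounds shown here, the only step that alters the group on the selenium is a 1.4-fold higher number from compound 1 to compound 3 (0.14 log units; within the scatter), within the scatter; the steps of a 5.2-fold higher number from compound 1 to compound 2 (0.72 log units; beyond the scatter) and a 3.7-fold lower number from compound 2 to compound 3 (0.57 log units; beyond the scatter) exchange the whole group on the aromatic carbon and do not bear directly on this change. Accordingly, in this assay no step beyond the scatter is expected, so compound 4 is estimated at 17000 nM, in the range 7000 nM to 40000 nM. The expected step of a 1.2-fold lower number from compound 3 to compound 4 (0.09 log units; within the scatter) is small.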

Compound 4, half-maximal effective concentration: 134000 nM
For compound 4 the middle estimate is 7.9-fold (0.90 log units) below the measured one; the whole stated range lies below it.
By their numbers in this assay, from the lowest: compounds 1 and 3 (each within the scatter of the next); then compounds 2 and 4 (each within the scatter of the next).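

In this assay, the group on the selenium proves able to shift the number beyond the scatter: 4-fluorophenyl replacing benzyl gives (a 6.4-fold higher number from compound 3 to compound 4 (0.81 log units; beyond the scatter)) and 4-fluorophenyl replacing 2-methylphenyl gives (a 9.0-fold higher number from compound 1 to compound 4 (0.95 log units; beyond the scatter)). The earlier benzyl and 2-methylphenyl pair showed no such shift. The exchange of the whole group on the aromatic carbon (a 1.7-fold higher number from compound 2 to compound 4 (0.24 log units; within the scatter)) stays within the scatter, but it alters selenium, tellurium and the fluorine together, so it separates none of them. Nothing measured here explains these shifts. Open, on these data alone, is how plain phenyl or 4-aminophenyl on the selenium would compare with 4-fluorophenyl.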